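Alkyl Variation on the Imidazole Arm of Compound 2

The source may report more compounds than this note shows. Statements on the series, on what has been measured and on what is new or still open speak of the compounds shown alone.

Compound 2 `Cn1cnc(CN2CCN(c3cccc4[nH]c(-c5ccc(C(C)(C)C)cc5)nc34)CC2)c1` gives 33 nM in an assay on isolated protein for displacement of a labelled ligand from Gonadotropin-releasing hormone receptor (Homo sapiens) (a higher number here means a weaker inhibitor, a lower number a stronger inhibitor), the second highest of three numbers. Compound 3 `CCCCc1nc(CN2CCN(c3cccc4[nH]c(-c5ccc(C(C)(C)C)cc5)nc34)CC2)cn1C` gives 26 nM, and the step of a 1.3-fold lower number from compound 2 to compound 3 (0.10 log units; within the scatter) falls within the scatter. Compound 1 `Cc1ccc(CN2CCN(c3cccc4[nH]c(-c5ccc(C(C)(C)C)cc5)nc34)CC2)o1` gives 705 nM, lying far off through a 21-fold lower number from compound 1 to compound 2 (1.33 log units; beyond the scatter) and a 27-fold lower number from compound 1 to compound 3 (1.43 log units; beyond the scatter). Compound 4 `CCCn1cc(CN2CCN(c3cccc4[nH]c(-c5ccc(C(C)(C)C)cc5)nc34)CC2)nc1C` differs from compound 2 by 2-methyl-1-propyl-1H-imidazol-4-yl in place of 1-methyl-1H-imidazol-4-yl on a saturated chain carbon bound to an amine nitrogen in a ring. Among the compounds with values here, the only measured step that bears on this change is a 1.3-fold lower number from compound 2 to compound 3 (0.10 log units; within the scatter), where butyl in place of hydrogen on an aromatic carbon of the same imidazole left the number within the scatter. No step beyond the scatter is therefore expected here, and the estimated step is a 1.2-fold lower number from compound 2 to compound 4 (0.07 log units; within the scatter). Compound 4 is expected to give 28 nM, in the range 11 nM to 70 nM.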

Compound 4, half-maximal inhibitory concentration: 18 nM
For compound 4 the middle estimate is 1.6-fold (0.19 log units) above the measured one; low and high end bracket the measured number.
By their numbers in this assay, from the lowest: compounds 4, 3 and 2 (each within the scatter of the next); then compound 1.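

In this assay, the 2-methyl-1-propyl-1H-imidazol-4-yl group holds the number of the earlier imidazoles, with a 1.8-fold lower number from compound 2 to compound 4 (0.26 log units; within the scatter) and a 1.4-fold lower number from compound 3 to compound 4 (0.16 log units; within the scatter) as its two steps, so this position also accepts a propyl in place of the methyl of compound 2. The distance from the furan stays large, at a 39-fold lower number from compound 1 to compound 4 (1.59 log units; beyond the scatter). No measurement offered here accounts for these numbers. The compounds shown do not separate the 2-methyl part of the change from the 1-propyl part. On these data alone, whether a longer chain such as hexyl, or a chain ending in a carboxylic acid, would hold the number on this imidazole stays open.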